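A Trifluoromethyl Swap in a Flat Fluorophenyl Series

The compounds below may be only part of what the source reports. "The series", "measured", "known", "first", "only" and "open" are said of these compounds alone.

In a functional assay with Homo sapiens as the target (a lower number here means a stronger inhibitor, a higher number a weaker inhibitor), compound 1 `CC(C)[C@H](NC(=O)COc1cccc2ccccc12)C(=O)N[C@@H](CC(=O)O)C(=O)COc1ccccc1F` gives 15700 nM and compound 2 `CC(C)[C@H](NC(=O)COc1cccc2ccccc12)C(=O)N[C@@H](CC(=O)O)C(=O)COc1ccc(F)cc1` gives 14300 nM. Compound 3 `CC(C)[C@H](NC(=O)COc1cccc2ccccc12)C(=O)N[C@@H](CC(=O)O)C(=O)COc1ccc(F)c(F)c1F` gives 20600 nM, which is within the scatter of both others. Compound 4 `CC(C)[C@H](NC(=O)COc1cccc2ccccc12)C(=O)N[C@@H](CC(=O)O)C(=O)COc1cccc(C(F)(F)F)c1F` differs from compound 3 as follows: 2-fluoro-3-(trifluoromethyl)phenyl in place of 2,3,4-trifluorophenyl on an oxygen on a saturated carbon. It has 2-fluoro-3-(trifluoromethyl)phenyl in place of 2,3,4-trifluorophenyl on an oxygen on a saturated carbon. Three measured steps changed this same group: a 1.1-fold lower number from compound 1 to compound 2 (0.04 log units; within the scatter), a 1.3-fold higher number from compound 1 to compound 3 (0.12 log units; within the scatter) and a 1.4-fold higher number from compound 2 to compound 3 (0.16 log units; within the scatter). Among the compounds with values here, all stayed within the scatter, but no measured compound carries trifluoromethyl, so the guide is imperfect. No step beyond the scatter is therefore expected, and the estimated change is a 1.1-fold lower number from compound 3 to compound 4 (0.06 log units; within the scatter). For compound 4, the expected value is 18000 nM, with an estimated range of 9000 nM to 36000 nM.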

Compound 4, half-maximal inhibitory concentration: 18200 nM
Beside the measured number, compound 4's estimate is 1.0-fold (0.00 log units) below it; low and high end bracket the measured number.
By their numbers in this assay, from the lowest: compounds 2, 1, 4 and 3 (each within the scatter of the next).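

Trifluoromethyl in place of hydrogen on an aromatic carbon gives a 1.2-fold higher number from compound 1 to compound 4 (0.06 log units; within the scatter), so in this assay this phenyl group on an oxygen on a saturated carbon accepts trifluoromethyl as flatly as it accepted extra fluorine. The other two swaps agree, with a 1.1-fold lower number from compound 3 to compound 4 (0.05 log units; within the scatter) and a 1.3-fold higher number from compound 2 to compound 4 (0.10 log units; within the scatter). No measured evidence is available that would explain this flat response.

The compounds shown leave open whether a group without fluorine on this phenyl, such as an amine or a nitrile, would behave the same way. They also leave open whether any change at this place can produce a step beyond the scatter.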